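A few compounds are considered here, and "the series" means these few. Any claim that something is new, unique, unknown or untested is made for them only; others in the source may bear on it.

Compound 1 `Nc1nc(N2CCN(C(=O)COc3ccc(Cl)cc3)CC2)c2nc(CCOc3ccc(F)cc3)sc2n1` gives 3540 nM in a functional assay on cells (Lymphocyte, Homo sapiens); a lower number here means a stronger inhibitor, a higher number a weaker inhibitor.
Compound 2 `CCCCCc1nc2c(N3CCN(C(=O)COc4ccc(Cl)cc4)CC3)nc(N)nc2s1` gives 690 nM in this assay.
Compound 3 `Nc1nc(N2CCN(C(=O)COc3ccc(Cl)cc3)CC2)c2nc(-c3ccncc3)sc2n1` gives 40 nM in this assay.

Among these three, compound 3 stands lowest in this assay: the steps of an 89-fold lower number from compound 1 to compound 3 (1.95 log units; beyond the scatter) and a 17-fold lower number from compound 2 to compound 3 (1.24 log units; beyond the scatter) both reach well beyond the scatter, while the step of a 5.1-fold lower number from compound 1 to compound 2 (0.71 log units; beyond the scatter) is the more modest of the three.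

Compound 4 `Nc1nc(N2CCN(C(=O)COc3ccc(Cl)cc3)CC2)c2nc(-c3ccccn3)sc2n1` is the next compound in this series. Its change from compound 3 is pyridin-2-yl in place of pyridin-4-yl on an aromatic carbon. Within the data shown here, no measured step exchanges one such ring for another; the measured steps only show that pyridin-4-yl on this aromatic carbon gives a far lower number than pentyl or 2-(4-fluorophenoxy)ethyl there. Since compound 4 keeps a six-membered aromatic ring with one nitrogen in the same place, the expected step of a 3.0-fold higher number from compound 3 to compound 4 (0.48 log units; beyond the scatter) is small, at most slightly toward a higher number, and may fall within the scatter. For compound 4 the estimated value in this assay is 120 nM, with a range from 30 nM to 500 nM.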

Compound 4, half-maximal inhibitory concentration: 230 nM
Estimate against measurement, compound 4: 1.9-fold (0.28 log units) below, and the stated range covers the measured number.
By their numbers in this assay, from the lowest: compound 3; then compound 4; then compound 2; then compound 1.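

In this assay, moving the ring nitrogen alone, with the same atoms and the same counts of donors and acceptors, is not a neutral exchange at this aromatic carbon (there is a 5.8-fold higher number from compound 3 to compound 4 (0.76 log units; beyond the scatter)), so pyridin-4-yl and pyridin-2-yl are not interchangeable here. Pyridin-2-yl still keeps a lower number than either chain (there is a 3.0-fold lower number from compound 2 to compound 4 (0.48 log units; beyond the scatter) and also a 15-fold lower number from compound 1 to compound 4 (1.19 log units; beyond the scatter)), so part of the advantage of pyridin-4-yl over pentyl and 2-(4-fluorophenoxy)ethyl survives the move, though only a modest step remains against pentyl. Nothing available explains why the place of the ring nitrogen changes the number.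

On these data alone, it remains open where pyridin-3-yl would fall relative to compound 3 and compound 4. Also open, as far as these compounds go, is whether a ring nitrogen is needed at all, which plain phenyl on this carbon would test.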